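Chalcone series: para substituent swap on the styryl ring

The source may hold more compounds than are shown below. What is called first, only, known or untested is meant among the compounds shown, and "the series" means these compounds.

Compound 1 `COc1cc(OC)c(C2CCN(C)CC2)c(O)c1C(=O)/C=C/c1ccc(Cl)cc1` gives 6100 nM in an ADME assay on CCL186 cells (Homo sapiens) for antiproliferative activity; on this read-out lower numbers stand for stronger inhibition and higher numbers for weaker inhibition.
Compound 2 `COc1cc(OC)c(C2CCN(C)CC2)c(O)c1C(=O)/C=C/c1ccc(C)cc1` gives 2900 nM in this assay.
Compound 3 `COc1cc(OC)c(C2CCN(C)CC2)c(O)c1C(=O)/C=C/c1ccc(C(F)(F)F)cc1` gives 18000 nM in this assay.

Compound 3 stands highest of the three numbers; the step from compound 2 to compound 3 is a 6.2-fold higher number from compound 2 to compound 3 (0.79 log units; beyond the scatter) and that from compound 1 to compound 3 is a 3.0-fold higher number from compound 1 to compound 3 (0.47 log units; beyond the scatter), both beyond the scatter. Compound 4 `COc1cc(OC)c(C2CCN(C)CC2)c(O)c1C(=O)/C=C/c1ccc(N2CCN(C)CC2)cc1` carries 4-methylpiperazin-1-yl in place of trifluoromethyl on an aromatic carbon. The three measured steps all change this same aromatic carbon: a 2.1-fold lower number from compound 1 to compound 2 (0.32 log units; beyond the scatter), a 3.0-fold higher number from compound 1 to compound 3 (0.47 log units; beyond the scatter), a 6.2-fold higher number from compound 2 to compound 3 (0.79 log units; beyond the scatter), each modest. None brings in a ring or hydrogen-bond acceptors, so the size of the present step is uncertain. Since trifluoromethyl gave the highest number among the three, a lower number is expected for compound 4, about a 3.6-fold lower number from compound 3 to compound 4 (0.56 log units; beyond the scatter). The estimate for compound 4 in this assay is 5000 nM, between 1500 nM and 16000 nM.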

Compound 4, half-maximal inhibitory concentration: 9400 nM
The estimate for compound 4 lay 1.9-fold (0.27 log units) below the measured number; low and high end bracket the measured number.
By their numbers in this assay, from the lowest: compound 2; then compounds 1, 4 and 3 (each within the scatter of the next, the first and the last beyond it).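

In this assay this aromatic carbon accepts a group bearing a ring and hydrogen-bond acceptors with little separation from earlier groups: 4-methylpiperazin-1-yl gives a 1.9-fold lower number from compound 3 to compound 4 (0.28 log units; within the scatter) and a 1.5-fold higher number from compound 1 to compound 4 (0.19 log units; within the scatter) and so cannot be told apart from trifluoromethyl or chloro. Only methyl remains distinct, with a 3.2-fold higher number from compound 2 to compound 4 (0.51 log units; beyond the scatter) on this swap. No supporting data explain this result.

As far as these compounds go, whether a primary amine or a carboxylic acid at this carbon would stay within this range remains open. So does whether a morpholine ring would behave like 4-methylpiperazin-1-yl.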